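Oxadiazole substituent, ethyl to phenyl, minimum effective dose

The source may hold more compounds than are shown below. What is called first, only, known or untested is meant among the compounds shown, and "the series" means these compounds.

compound 1 `CCc1c(OC)nc2nc(-c3nnco3)cn2c1C`: > 50 mg/kg
compound 2 `CCc1nnc(-c2cn3c(C)c(CC)c(OC)nc3n2)o1`: 50 mg/kg

In a functional assay on the whole organism with Rattus norvegicus as the target (on this read-out lower numbers stand for an effect already at smaller amounts and higher numbers for an effect only at larger amounts of compound), compound 1 reaches only a limit of the assay, > 50 mg/kg. Among the compounds with values here, compound 2 gives 50 mg/kg in this assay, the only number among the two values shown. The step of a number no higher from compound 1 to compound 2 (the limit leaves the size open) has no readable size because compound 1 sits at the limit of > 50 mg/kg in this assay, at which 1 of the 2 values shown sits.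

Compound 3 `CCc1c(OC)nc2nc(-c3nnc(-c4ccccc4)o3)cn2c1C` differs from compound 2 by phenyl in place of ethyl on an aromatic carbon. Within the data shown here, the single measured step touches the same five-membered ring, but its size is open, so it gives no direction for the expected effect. With no readable step behind it, compound 3 is estimated near compound 2, at 40 mg/kg (10 mg/kg to 100 mg/kg). That estimate means an expected step of a 1.3-fold lower number from compound 2 to compound 3 (0.10 log units; within the scatter).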

Compound 3, minimum effective dose: > 50 mg/kg
Compound 3 gave a limit, no number (the forecaster's own chance of this, stated with the estimate: 40%); middle value at least 1.2-fold (0.09 log units) from the limit.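

On the aromatic carbon of the five-membered ring, phenyl gives no number in this assay: compound 3 reaches only a limit, > 50 mg/kg. Replacing ethyl with phenyl therefore shows no gain at this position, only a number no lower from compound 2 to compound 3 (the limit leaves the size open), and neither step to compound 3 can be read in size. The series remains mostly bounded at this position: the limit of > 50 mg/kg in this assay, at which 2 of the 3 values shown sit.

Open, as far as these compounds go, is whether a longer chain such as propyl, an amine or a carboxylic acid on this carbon would give a number that can be set against compound 2 at 50 mg/kg.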